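The compounds below may be only part of what the source reports. "The series", "measured", "known", "first", "only" and "open" are said of these compounds alone.

Among the measured compounds shown here, in a functional assay (strain AB) with Danio rerio as the target, read by microscopy, with a stated time of 1 h (a lower number here means that less compound is needed, a higher number that more compound is needed for the effect), compound 3 `CC(C)(C)OC(=O)CCN1CCc2c(sc(NC(=O)Nc3ccc(Cl)cc3)c2C(N)=O)C1` gives 1100 nM, the lower of the two numbers so far, and compound 2 `CC(C)(C)CN1CCc2c(sc(NC(=O)Nc3ccc(Cl)cc3)c2C(N)=O)C1` gives 5560 nM. Compound 1 `CC(C)(C)OC(=O)N1CCc2c(sc(NC(=O)Nc3ccc(Cl)cc3)c2C(N)=O)C1` sits at a limit of the assay, > 25000 nM. Compound 4 `COCCCN1CCc2c(sc(NC(=O)Nc3ccc(Cl)cc3)c2C(N)=O)C1` differs from compound 3 by methoxymethyl in place of tert-butoxycarbonyl on a saturated chain carbon, two bonds along the chain from an amine nitrogen in a ring. The closest measured step is the modest 5.1-fold lower number from compound 2 to compound 3 (0.70 log units; beyond the scatter), which also brings in tert-butoxycarbonyl. Further off stand an at least 4.4-fold lower number from compound 1 to compound 2 (0.65 log units; beyond the scatter) and the large at least 22-fold lower number from compound 1 to compound 3 (1.35 log units; beyond the scatter). Part of that modest step is expected to reverse, so the expected change is a 2.3-fold higher number from compound 3 to compound 4 (0.36 log units; beyond the scatter), towards a higher number. For compound 4 the estimate is 2500 nM, with an expected range of 700 nM to 9000 nM.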

Compound 4, half-maximal effective concentration: 2400 nM
Beside the measured number, compound 4's estimate is 1.0-fold (0.02 log units) above it; measured number inside the range.
By their numbers in this assay, from the lowest: compound 3; then compound 4; then compound 2. At a limit, above all of these: compound 1.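

In this assay, the carbonyl of the ester chain is not required for a number lower than that of the neopentyl chain: the change to methoxymethyl gives a 2.2-fold higher number from compound 3 to compound 4 (0.34 log units; beyond the scatter), while 2-methoxyethyl in place of tert-butyl gives a 2.3-fold lower number from compound 2 to compound 4 (0.36 log units; beyond the scatter). With 3-methoxypropyl in place of tert-butoxycarbonyl on the amine nitrogen in a ring, the step is an at least 10-fold lower number from compound 1 to compound 4 (1.01 log units; beyond the scatter). Compound 1 stands only as a limit: the limit of > 25000 nM in this assay, at which 1 of the 4 values shown sits.

Still open, on these data alone, is whether the gap between the two chains follows the carbonyl or the tert-butyl part of the ester. A methyl ester, a carboxylic acid or an amine at the end of the chain would separate these.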